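The source may hold more compounds than are shown below. What is called first, only, known or untested is meant among the compounds shown, and "the series" means these compounds.

Measured so far in a functional assay on Bel-7402 cells (Homo sapiens) for cytotoxicity, read by MTT assay, with a stated time of 48 h; a lower number here means a stronger inhibitor, a higher number a weaker inhibitor: compound 1 `CCn1cc(-c2nc3ccccc3s2)c(=O)c2cc(F)c(N3CCNCC3)cc21` gives 24300 nM; compound 2 `CCn1cc(-c2nc3ccccc3s2)c(=O)c2cc(F)c(N3CCNCC3)nc21` gives 2400 nM; compound 3 `CCn1cc(-c2nc3ccc(Cl)cc3[nH]2)c(=O)c2cc(F)c(N3CCNCC3)nc21` gives 21500 nM.

Compounds 1 and 2 share most of their structure, but the difference between their two cores is not broken down here; their values show that compound 2 gives the lower number of the two. Compound 3 differs from compound 2 by 6-chloro-1H-benzimidazol-2-yl in place of 1,3-benzothiazol-2-yl on an aromatic carbon, and that change made a 9.0-fold higher number from compound 2 to compound 3 (0.95 log units; beyond the scatter). The values of compound 1 and compound 3 lie within the usual scatter of each other, so nothing separates them.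

Compound 4 `CCn1cc(-c2nc3ccc(Cl)cc3[nH]2)c(=O)c2cc(F)c(N3CCNCC3)cc21` has not yet been measured. It differs from compound 1 by 6-chloro-1H-benzimidazol-2-yl in place of 1,3-benzothiazol-2-yl on an aromatic carbon, the same change at the same place as in the measured pair. For compound 4 the expected step is a 4.1-fold higher number from compound 1 to compound 4 (0.61 log units; beyond the scatter), resting on the measured step of a 9.0-fold higher number from compound 2 to compound 3 (0.95 log units; beyond the scatter). Because compound 1 already gives 24300 nM, a step of that size pushes toward the edge of what this assay can report as a number. Compound 4 is therefore estimated at about 100000 nM, with a range from 30000 nM to 400000 nM.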

Compound 4, half-maximal inhibitory concentration: 2800 nM
Compound 4: middle estimate off by 36-fold (1.55 log units), on the high side, and the stated range ends above it.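

In this assay, 6-chloro-1H-benzimidazol-2-yl in place of 1,3-benzothiazol-2-yl gave an 8.7-fold lower number from compound 1 to compound 4 (0.94 log units; beyond the scatter), so on the core of compound 1 the change ran the opposite way to its course on the core of compound 2. The two steps are close in size but opposite in direction, and they do not agree: the same change on two cores in this assay, a 9.0-fold higher number (0.95 log units; beyond the scatter) from compound 2 to compound 3 and an 8.7-fold lower number (0.94 log units; beyond the scatter) from compound 1 to compound 4, 78-fold (1.89 log units) apart, beyond the scatter of two such steps

This shows that, across these two cores, neither the size nor the direction of the change carries over from one to the other, though it does not show why the steps differ or how the change would behave on any further core.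

The compounds shown leave open which part of the difference between the two cores turns the step around. They also leave open whether the chlorine or the rest of the entering group matters, and how a plain 1H-benzimidazol-2-yl or a 1,3-benzoxazol-2-yl would behave on either core.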